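The source may hold more compounds than are shown below. What is called first, only, known or untested is meant among the compounds shown, and "the series" means these compounds.

Measured compounds:
compound 1, `C=C1CC[C@@H]2[C@](C)(COC(C)=O)[C@H](O)CC[C@@]2(C)[C@@H]1C/C=C1/C(=O)OC[C@@H]1Oc1c(Cl)cc(Cl)c2cccnc12`, 51900 nM;
compound 2, `C=C1CC[C@@H]2[C@](C)(COC(C)=O)[C@H](O)CC[C@@]2(C)[C@@H]1C/C=C1/C(=O)OC[C@@H]1Oc1cccc2ccc(C)nc12`, 46500 nM;
compound 3, `C=C1CC[C@H]2[C@@](C)(CCC(=O)[C@@]2(C)COC(C)=O)[C@@H]1C/C=C1/C(=O)OC[C@@H]1Oc1cccc2ccc(C)nc12`, 46700 nM.

These three were tested in an ADME assay on Vero cells (Chlorocebus sabaeus) for cytotoxicity, read by MTT assay, with a stated time of 48 h; on this read-out higher numbers stand for lower toxicity in this test and lower numbers for higher toxicity in this test. Compound 1 and compound 2 share a core and differ by 5,7-dichloroquinolin-8-yl in place of 2-methylquinolin-8-yl on an oxygen on a saturated carbon; that change gave a 1.1-fold higher number from compound 2 to compound 1 (0.05 log units; within the scatter). Compound 3 carries the other core; the difference between the two cores is not broken down here, and the values of compound 2 and compound 3 lie within the scatter of each other.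

Compound 4, `C=C1CC[C@H]2[C@@](C)(CCC(=O)[C@@]2(C)COC(C)=O)[C@@H]1C/C=C1/C(=O)OC[C@@H]1Oc1c(Cl)cc(Cl)c2cccnc12`, has not yet been measured. It differs from compound 3 by 5,7-dichloroquinolin-8-yl in place of 2-methylquinolin-8-yl on an oxygen on a saturated carbon, the same change as from compound 2 to compound 1, made on the same kind of place. Because that earlier step was a 1.1-fold higher number from compound 2 to compound 1 (0.05 log units; within the scatter), the step for compound 4 is expected to be a 1.1-fold higher number from compound 3 to compound 4 (0.03 log units; within the scatter). For compound 4 the value estimated in this assay is 50000 nM, expected to lie between 30000 nM and 85000 nM.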

Compound 4, half-maximal cytotoxic concentration: 57400 nM
Compound 4: middle estimate off by 1.1-fold (0.06 log units), on the low side; measured number inside the range.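

In this assay, 5,7-dichloroquinolin-8-yl in place of 2-methylquinolin-8-yl gave a 1.2-fold higher number from compound 3 to compound 4 (0.09 log units; within the scatter) on the core shared by these two compounds. Set beside the earlier step, the change behaved alike on both cores, with no difference that can be told apart: the same change on two cores in this assay, a 1.1-fold higher number (0.05 log units; within the scatter) from compound 2 to compound 1 and a 1.2-fold higher number (0.09 log units; within the scatter) from compound 3 to compound 4, 1.1-fold (0.04 log units) apart, within the scatter of two such steps. This shows that the change stayed within the scatter on both cores, but because neither step is larger than the scatter, it does not show that a real effect carries from one core to the other, and two cores support no general rule.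

The compounds shown leave open whether a group carrying an amine or a carboxylic acid, in place of the quinolinyl group on that oxygen, would move the number beyond the scatter.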